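The source may hold more compounds than are shown below. What is called first, only, known or untested is meant among the compounds shown, and "the series" means these compounds.

Compound 1 `N#Cc1c(O)nc(SCc2nc3ccccc3[nH]2)nc1-c1ccccc1`: 7.7 nM
Compound 2 `N#Cc1c(NNC(N)=S)nc(SCc2nc3ccccc3[nH]2)nc1-c1ccccc1`: 3.2 nM

Both compounds were tested in a functional assay on SK-MEL-28 cells (Homo sapiens) for cytotoxicity, read by MTT assay, with a stated time of 3 days; a higher number here means a weaker inhibitor, a lower number a stronger inhibitor. Of the two numbers, compound 2 has the lower at 3.2 nM, while compound 1 stands at 7.7 nM. The next compound, compound 3 `N#Cc1c(NC(N)=O)nc(SCc2nc3ccccc3[nH]2)nc1-c1ccccc1`, has not yet been measured in this assay. It keeps the shared core and alters only the chain that compound 2 carries: a group of 3 heavy atoms (1 carbon, 1 nitrogen, 1 oxygen; no ring) in place of a group of 4 heavy atoms (1 carbon, 2 nitrogen, 1 sulfur; no ring), on a nitrogen on an aromatic ring. The incoming group is a carbamoyl, placed on a nitrogen on an aromatic ring.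

Within the data shown here, only one measured step bears on this change, a 2.4-fold lower number from compound 1 to compound 2 (0.38 log units; beyond the scatter). That step is modest and lies beyond the scatter, and it was made at the same aromatic carbon, where the chain of compound 2 replaced one oxygen atom. It shows that changes here can move the number, but only moderately. The data hold no direct comparison of these two chains, so a small move towards a higher number is expected, perhaps not beyond the scatter. The expected step is a 1.6-fold higher number from compound 2 to compound 3 (0.19 log units; within the scatter). Compound 3 is estimated at 5 nM, with an expected range of 1.5 nM to 17 nM.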

Compound 3, half-maximal inhibitory concentration: 4.8 nM
Compound 3: middle estimate off by 1.0-fold (0.02 log units), on the high side, and the stated range covers the measured number.
By their numbers in this assay, from the lowest: compounds 2, 3 and 1 (each within the scatter of the next, the first and the last beyond it).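

In this assay the change from the chain of compound 2 to carbamoyl, on a nitrogen on an aromatic ring, gives a step within the scatter (a 1.5-fold higher number from compound 2 to compound 3 (0.18 log units; within the scatter)), and this is the first step shown at that nitrogen. Ureido in place of hydroxy on the aromatic carbon also stays within the scatter (a 1.6-fold lower number from compound 1 to compound 3 (0.21 log units; within the scatter)), whereas the chain of compound 2 at that same carbon gave a step beyond it, so compound 3 cannot be told apart from either neighbour, and only compound 1 and compound 2 remain separated. Nothing in the data explains these numbers.

The step from compound 2 to compound 3 removes a sulfur and a nitrogen and brings in an oxygen all at once, so the compounds shown cannot say whether the exchange of sulfur for oxygen or the shorter chain matters more. From the compounds shown here alone, it also remains open whether a plain amine on that aromatic carbon, or a longer chain on the nitrogen, would move the number beyond the scatter.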